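The compounds below may be only part of what the source reports. "The series", "measured", "known", "first", "only" and "open" are said of these compounds alone.

For the measured compounds named here, compound 2 `CCCC1=C(OC)C(CCC)(CCC)C(=O)/C(=C(O)\C=C\c2ccc(I)cc2)C1=O` is the one compound of this set with a number to its name: in a functional assay on MCF7 cells (Homo sapiens) for antiproliferative activity, read by sulforhodamine B assay, with a stated time of 3 days (on this read-out lower numbers stand for an effect already at smaller amounts and higher numbers for an effect only at larger amounts of compound), compound 2 gives 1.8 uM. Its two companions, compound 1 `CCCC1=C(OC)C(CCC)(CCC)C(=O)/C(=C(O)\C=C\c2ccccc2)C1=O`, for which this assay records "not determined" (no result reported), and compound 3 `CCCC1=C(OC)C(CCC)(CCC)C(=O)/C(=C(O)\C=C\c2ccc(Br)cc2)C1=O`, for which this assay records "not determined" (no result reported), were run without a result being reported, so compound 2 stands alone as the single point of reference. The next compound, compound 4 `CCCOC1=C(CCC)C(=O)/C(=C(O)/C=C/c2ccc(I)cc2)C(=O)C1(CCC)CCC`, has not yet been tested. It differs from compound 2 in one place: ethyl in place of hydrogen on a saturated chain carbon bound to an oxygen on an unsaturated carbon, which read one bond further out is methoxy becoming propoxy. Going by the values given here, no step between two measured compounds exists to lean on, so the expected step from compound 2 to compound 4 in this assay is small, a 1.1-fold higher number from compound 2 to compound 4 (0.05 log units; within the scatter), within the usual scatter in either direction. Compound 4 is therefore estimated at 2 uM, between 0.7 uM and 6 uM.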

Compound 4, concentration for half-maximal effect: 5.1 uM
Compound 4: middle estimate off by 2.6-fold (0.41 log units), on the low side; low and high end bracket the measured number.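

Widening methoxy to propoxy is the first change at this position that can be read, and in this assay it gives a 2.8-fold higher number from compound 2 to compound 4 (0.45 log units; beyond the scatter) and so is not silent. This position therefore responds to added ethyl, though only modestly and only in this one pair, on the iodinated compounds. Nothing on hand explains the step.

From the compounds shown here alone, whether ethoxy, a longer chain such as butoxy, or an amine-bearing chain on this oxygen would continue the same direction remains open. Steps involving compound 1 and compound 3 cannot be read.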